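From 2-methyl-3-nitrophenyl to 2-ethylphenyl

This account rests on a few compounds, and the source may have more. Where it says the series, first, only, none or still open, it means among the compounds named here.

In a functional assay on A549 cells (Homo sapiens) for antiproliferative activity, read by MTT assay (a lower number here means a stronger inhibitor, a higher number a weaker inhibitor), compound 3 `Cc1c(-n2cc(COc3ccc(/C=C/C(=O)c4ccc5c(c4O)CCC(C)(C)O5)cc3)nn2)cccc1[N+](=O)[O-]` has no number and is reported as "not active" (no number reported). Compound 1 `CC1(C)CCc2cc(C(=O)/C=C/c3ccc(OCc4cn(-c5ccc(Br)cc5)nn4)cc3)c(O)cc2O1` gives 80000 nM and compound 2 `COc1ccc(-n2cc(COc3ccc(/C=C/C(=O)c4cc5c(cc4O)OC(C)(C)CC5)cc3)nn2)c([N+](=O)[O-])c1` gives 99500 nM. Both carry a core that differs from that of compound 3. Compound 4 `CCc1ccccc1-n1cc(COc2ccc(/C=C/C(=O)c3ccc4c(c3O)CCC(C)(C)O4)cc2)nn1` keeps the core of compound 3 and has one change: 2-ethylphenyl in place of 2-methyl-3-nitrophenyl on an aromatic nitrogen. Among the compounds with values here, the only measured exchange on that aromatic nitrogen is a 1.2-fold higher number from compound 1 to compound 2 (0.09 log units; within the scatter), so the exchange alone is not expected to produce a step beyond the scatter. With no number to step from, the expectation rests on the values of the two measured compounds, and another report without a number remains possible. For compound 4, the estimated value is 80000 nM, with an expected range of 30000 nM to 200000 nM.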

Compound 4, half-maximal inhibitory concentration: 112000 nM
Compound 4: the middle estimate sits 1.4-fold (0.15 log units) below what was measured; low and high end bracket the measured number.
By their numbers in this assay, from the lowest: compounds 1, 2 and 4 (each within the scatter of the next).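

Within the data shown here, compound 4 gives 112000 nM in this assay but compound 3 has no number, so no step between compound 3 and compound 4 can be read. On these data alone, whether exchanging 2-methyl-3-nitrophenyl for 2-ethylphenyl changes activity on this core stays open. No evidence on the result is available.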